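Adding a nitro group to compound 1

This account rests on a few compounds, and the source may have more. Where it says the series, first, only, none or still open, it means among the compounds named here.

- compound 1 `COc1ccc(CN(C(=O)CSC(=S)N2CCN(C(=O)OC(C)(C)C)CC2)c2cc(OC)c(OC)c(OC)c2)cc1`: 310 nM
- compound 2 `COc1ccc(CN(C(=O)CSC(=S)N2CCN(Cc3ccc(C(C)(C)C)cc3)CC2)c2cc(OC)c(OC)c(OC)c2)cc1`: 5390 nM
- compound 3 `COc1ccc(CN(C(=O)CSC(=S)N2CCN(C(=O)OC(C)(C)C)CC2)c2ccc(OC)cc2)cc1`: > 20000 nM (a limit of the assay, not a number)

In a functional assay on MGC-803 cells (Homo sapiens) for inhibition, read by CCK-8 assay, with a stated time of 48 h (on this read-out higher numbers stand for weaker inhibition and lower numbers for stronger inhibition), compound 1 has the lower of the two numbers, and the nearest step is a 17-fold higher number from compound 1 to compound 2 (1.24 log units; beyond the scatter). Compound 4 `COc1ccc(CN(C(=O)CSC(=S)N2CCN(C(=O)OC(C)(C)C)CC2)c2cc(OC)c(OC)c(OC)c2)cc1[N+](=O)[O-]` differs from compound 1 by nitro in place of hydrogen on an aromatic carbon, turning 4-methoxybenzyl into 4-methoxy-3-nitrobenzyl. Going by the values given here, no measured step alters that group. The step of a 17-fold higher number from compound 1 to compound 2 (1.24 log units; beyond the scatter) places 4-(tert-butyl)benzyl in place of tert-butoxycarbonyl, and the step of an at least 64-fold higher number from compound 1 to compound 3 (1.80 log units; beyond the scatter) places 4-methoxyphenyl in place of 3,4,5-trimethoxyphenyl. Both are large and upward, but they bear only indirectly, so a smaller rise in this assay is expected. The expected step is a 2.6-fold higher number from compound 1 to compound 4 (0.41 log units; beyond the scatter). Compound 4 is estimated at 800 nM, with an expected range of 150 nM to 5000 nM.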

Compound 4, half-maximal inhibitory concentration: 880 nM
The estimate for compound 4 lay 1.1-fold (0.04 log units) below the measured number, within the range that was stated.
By their numbers in this assay, from the lowest: compound 1; then compound 4; then compound 2. At a limit, above all of these: compound 3.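

In this assay, placing nitro ortho to a methoxy group turns 4-methoxybenzyl into 4-methoxy-3-nitrobenzyl and gives a 2.8-fold higher number from compound 1 to compound 4 (0.45 log units; beyond the scatter). This is the first change shown on this group: the step is modest, and the added nitro leaves a measured number rather than a limit of the assay. Nothing shown accounts for the rise.

From the compounds shown here alone, whether the rise is specific to nitro remains open, and an amine or a fluorine atom at this position would test that. Also open, going by these compounds, is whether the step would persist with 4-(tert-butyl)benzyl in place of tert-butoxycarbonyl.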